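Nitro for Fluoro on the Benzothiazole of a Porcupine Inhibitor

The source may hold more compounds than are shown below. What is called first, only, known or untested is meant among the compounds shown, and "the series" means these compounds.

Among the measured compounds shown here, compound 2 `O=C(CNC(=O)c1nn(-c2ccccc2)c(=O)c2ccccc12)Nc1nc2ccc(F)cc2s1` is the only compound with a number in an assay on L cells for inhibition of Protein-serine O-palmitoleoyltransferase porcupine (Mus musculus), read by reporter gene assay, with a stated time of 24 h (on this read-out lower numbers stand for an effect already at smaller amounts and higher numbers for an effect only at larger amounts of compound), where compound 2 gives 470 nM. Compound 1 `O=C(CNC(=O)c1nn(-c2ccc(F)cc2)c(=O)c2ccccc12)Nc1nc2ccccc2s1` reaches only the limit of this assay, > 25000 nM, as recorded in the limit of > 25000 nM in this assay, at which 1 of the 2 values shown sits. Compound 3 `O=C(CNC(=O)c1nn(-c2ccccc2)c(=O)c2ccccc12)Nc1nc2ccc([N+](=O)[O-])cc2s1` differs from compound 2 by nitro in place of fluoro on an aromatic carbon. For the measured compounds named here, no step between measured compounds is available, so the outlook rests on the structural change alone. The account expects compound 3 to stay near compound 2, with a step of a 1.7-fold higher number from compound 2 to compound 3 (0.23 log units; within the scatter) that may edge beyond the scatter toward weaker potency. Compound 3 is estimated at 800 nM, within 150 nM to 5000 nM.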

Compound 3, half-maximal effective concentration: 240 nM
Beside the measured number, compound 3's estimate is 3.3-fold (0.52 log units) above it; the range from low to high includes it.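

In this assay nitro in place of fluoro on this aromatic carbon gives a 2.0-fold lower number from compound 2 to compound 3 (0.29 log units; within the scatter) and so leaves the two compounds indistinguishable on this read-out. The position, para to a fused ring, thus accepts 6-nitro-1,3-benzothiazol-2-yl as well as 6-fluoro-1,3-benzothiazol-2-yl, although nitro brings more heavy atoms and two hydrogen-bond acceptors. Nothing measured here bears on why the two groups match. On these data alone, whether an amine or a carboxylic acid would hold this level at the same position stays open. So does what plain hydrogen there would give on compound 2.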